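A few compounds are considered here, and "the series" means these few. Any claim that something is new, unique, unknown or untested is made for them only; others in the source may bear on it.

Working notes on the series. Compound 1 (`C=CC(=O)N1C(=O)CC(c2ccc(C)cc2)Sc2ccccc21`) gives 37300 nM in a functional assay on NB-4 cells (Homo sapiens) for cytotoxicity, read by CCK-8 assay, with a stated time of 24 h (a lower number here means a stronger inhibitor, a higher number a weaker inhibitor), and stands level with the other two measured compounds, all three lying within the scatter of one another. Compound 2 (`C=CC(=O)N1C(=O)CC(c2ccc(OC)cc2)Sc2ccccc21`) gives 32900 nM in this assay and compound 3 (`C=CC(=O)N1C(=O)CC(c2ccccc2C(F)(F)F)Sc2ccccc21`) gives 35200 nM on the same read-out.

The open compound is compound 4 (`C=CC(=O)N1C(=O)CC(c2ccc(C(=O)OC)cc2)Sc2ccccc21`), which keeps the core of compound 1 and alters one substituent. The change is methoxycarbonyl in place of methyl on an aromatic carbon and reads as methoxycarbonyl in place of methyl on an aromatic carbon, para to a large group.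

Among the compounds with values here, one measured step bears on it directly, since it also replaces the methyl of compound 1: a 1.1-fold lower number from compound 1 to compound 2 (0.05 log units; within the scatter) is the only such step, and it stays within the scatter. Compound 3, which has a trifluoromethyl group and no methyl, also stays within the scatter of compound 1. Within the data shown here, no measured compound carries methoxycarbonyl, so the enlarged group remains untested and the range is kept wide.

The flat values give no ground for a step in either direction. The estimated step is a 1.1-fold lower number from compound 1 to compound 4 (0.04 log units; within the scatter) and nothing beyond the scatter is expected. In this assay compound 4 is estimated at 34000 nM (expected range 17000 nM to 65000 nM).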

Compound 4, half-maximal inhibitory concentration: 24400 nM
Compound 4: the middle estimate sits 1.4-fold (0.14 log units) above what was measured; low and high end bracket the measured number.
By their numbers in this assay, from the lowest: compounds 4, 2, 3 and 1 (each within the scatter of the next).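

In this assay, the step of a 1.5-fold lower number from compound 1 to compound 4 (0.18 log units; within the scatter) shows that methoxycarbonyl, which has more heavy atoms than methyl and carries hydrogen-bond acceptors where methyl has none, can sit on this aromatic carbon, para to a large group, without a step beyond the scatter. Exchanging one oxygen-bearing group for another at the same place gives the same picture, with a 1.3-fold lower number from compound 2 to compound 4 (0.13 log units; within the scatter), so methyl, methoxy and methoxycarbonyl are not told apart here. The data offer no measurement that could account for these numbers, and no reason can be given for them.

As far as these compounds go, whether a carboxylic acid, an amine or an ester with a longer chain on this aromatic carbon would give a step beyond the scatter in this assay remains open. The compounds shown also vary only the aromatic substituent, so they leave open how much of the activity rests on the shared core and on the acryloyl group it carries, and a compound without that acryloyl group would be needed to address this.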